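The source may hold more compounds than are shown below. What is called first, only, known or untested is meant among the compounds shown, and "the series" means these compounds.

Measured so far in a functional assay (trachea) for antagonist activity, with Cavia porcellus as the target; a lower number here means a less potent compound, a higher number a more potent compound, by a factor of ten per unit of this negative logarithm:

Compound 1 `COC(=O)C(C(=O)c1ccc(Cn2ccc3ccc(NC(=O)CC4CCCC4)cc32)c(OC)c1)S(=O)(=O)c1ccccc1` gives 10.1.
Compound 2 `CCCCC(CC)C(=O)Nc1ccc2ccn(Cc3ccc(C(=O)NS(=O)(=O)c4ccccc4)cc3OC)c2c1` gives 8.6.
Compound 3 `CCCCC(CC)C(=O)Nc1ccc2ccn(Cc3ccc(C(=O)NS(=O)(=O)c4ccc(Cl)cc4)cc3OC)c2c1` gives 7.8.

Compound 3 stands lowest of the three numbers in this assay. Its nearest neighbour is compound 2, and the one move that separates them, a number 0.80 log units lower from compound 2 to compound 3 (beyond the scatter), is the only measured step among these compounds. Among the compounds with values here, compound 1 lies further away still and shares no single-point step with compound 3.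

The next compound, compound 4 `CCCCC(CC)C(=O)Nc1ccc2ccn(Cc3ccc(C(=O)NS(=O)(=O)c4ccc(C)cc4)cc3OC)c2c1`, differs from compound 3 in one place: methyl in place of chloro on an aromatic carbon. Within the data shown here, no measured step shows methyl in place of chloro directly. What the numbers do show is that the ring bearing hydrogen at this spot, in compound 2, scored higher than the ring bearing chloro, in compound 3, by a modest amount beyond the scatter. A methyl at the same spot is a different group again, so the best that can be said is that compound 4 is expected to land somewhere near compound 3, most likely between compound 3 and compound 2, with the estimated step in this assay being a number 0.30 log units higher from compound 3 to compound 4 (within the scatter).

Compound 4 is therefore estimated at 8.1, within a range from 7.5 to 8.7.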

Compound 4, negative logarithm of the antagonist equilibrium constant: 8.4
Estimate against measurement, compound 4: 0.30 log units below, within the range that was stated.
By their numbers in this assay, from the lowest: compound 3; then compounds 4 and 2 (each within the scatter of the next); then compound 1.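

In this assay, methyl in place of chloro on the aromatic carbon para to a large group gives a clear change (a number 0.60 log units higher from compound 3 to compound 4 (beyond the scatter)), even though each group counts one heavy atom and no hydrogen-bond donors or acceptors, so these counts do not separate the two. Methyl in place of hydrogen at the same spot gives a step that cannot be told from the scatter (a number 0.20 log units lower from compound 2 to compound 4 (within the scatter)), so among these three rings only chloro stands apart, with a number beyond the scatter from both hydrogen and methyl. No measurement here accounts for the difference between chloro and methyl at this position.

The compounds shown leave open how this position would respond to a group of another kind, such as an amine, a carboxylic acid or a longer chain such as propyl. They also leave open whether chloro or methyl on the phenyl ring of compound 1, whose core differs from that of the other three, would give steps of the same direction and size.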